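Methyl in place of isopropyl: the case of compound 4

The source may report more compounds than this note shows. Statements on the series, on what has been measured and on what is new or still open speak of the compounds shown alone.

Three compounds built on a shared core have been put through a physicochemical assay for permeability, using PAMPA; a higher number here means that the compound crosses the layer faster, a lower number that the compound crosses the layer more slowly. Compound 1 `Cc1cc(C)c(-c2nc(CN3CCC(C(=O)NCCCN4C[C@H](C)C[C@H](C)C4)CC3)c(C)o2)c(C)c1` stands as "not determined" (no result reported), so it offers nothing to compare.

Compound 2 `Cc1ccccc1-c1nc(CN2CCC(C(=O)NCCCN3CC(C)(C)CC(C)(C)C3)CC2)c(C)o1` reads > 1390 10^-6 cm/s, which is a limit of the assay and not a number.

Among the compounds with values here, compound 3 `Cc1ccccc1-c1nc(CN2CCC(C(=O)NCCCN3CCC(C(C)C)CC3)CC2)c(C)o1` gives 396 10^-6 cm/s, the only true number among the three.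

Compound 4 `Cc1ccccc1-c1nc(CN2CCC(C(=O)NCCCN3CCC(C)CC3)CC2)c(C)o1` has not yet been measured. It differs from compound 3 by methyl in place of isopropyl on a saturated ring carbon, so that 4-isopropylpiperidin-1-yl becomes 4-methylpiperidin-1-yl.

Within the data shown here, one measured step bears on this change, and only indirectly. That step is an at least 3.5-fold lower number from compound 2 to compound 3 (0.54 log units; beyond the scatter), which lies beyond the scatter and also made the group at the end of the chain smaller. As far as these compounds go, it starts from a limit, so its true size stays open, and it is a single example at a different place on the ring.

Following the direction of that one step, a lowering is expected again in this assay, estimated as a 2.6-fold lower number from compound 3 to compound 4 (0.42 log units; beyond the scatter).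

Compound 4 is estimated at 150 10^-6 cm/s, with an expected range from 50 10^-6 cm/s to 400 10^-6 cm/s.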

Compound 4, apparent permeability: 425 10^-6 cm/s
The estimate for compound 4 lay 2.8-fold (0.45 log units) below the measured number; the measured number lies above the stated range.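

In this assay, within the data shown here, the change at this position reads as a 1.1-fold higher number from compound 3 to compound 4 (0.03 log units; within the scatter), so with methyl in place of isopropyl on this saturated ring carbon, three ring bonds from the ring nitrogen, the two compounds cannot be told apart; the earlier compounds offered no step at this place. Going further down the substituent on this carbon does not extend the earlier step in its direction: an at least 3.2-fold lower number from compound 2 to compound 4 (0.51 log units; beyond the scatter) stands alongside an at least 3.5-fold lower number from compound 2 to compound 3 (0.54 log units; beyond the scatter), and both lie beyond the scatter while the 4-isopropylpiperidin-1-yl and 4-methylpiperidin-1-yl compounds stay within it of each other. Compound 2 stands at a limit of the assay, which is not a number, and both of those steps begin there: the limit of > 1390 10^-6 cm/s in this assay, at which 1 of the 4 values shown sits.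

As far as these compounds go, whether a hydroxyl, an amine or a carboxylic acid on this ring carbon would read like methyl and isopropyl stays open, as does the reading of a plain piperidin-1-yl with no group there at all. From the compounds shown here alone, the true size of the two steps that begin at the limit also stays open, as does whether a longer chain such as n-butyl at this carbon would leave the number where these two groups put it.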